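The source may hold more compounds than are shown below. What is called first, only, known or untested is meant among the compounds shown, and "the series" means these compounds.

Compound 1 `Cc1ccc(-c2cnn3c(NCc4ccccn4)cc(C)nc23)cc1` was examined in a physicochemical assay for solubility, read by HPLC, using the shake flask method, measured as kinetic solubility, with a stated time of 2 h, at pH 7.4; a lower number here means a less soluble compound, a higher number a more soluble compound. In this assay compound 1 gives < 5000 nM, which is a limit of the assay rather than a number, so where compound 1 truly stands is known only as far as that limit (the limit of < 5000 nM in this assay, at which 1 of the 2 values shown sits). A second measured compound, compound 2 `Cc1cc(N(C)Cc2ccccn2)n2nc(C)c(-c3ccccc3)c2n1`, gives 17500 nM in this assay. Compound 3 `Cc1cc(NCc2ccccn2)n2ncc(-c3ccsc3)c2n1` has not yet been measured; it differs from compound 1 by thiophen-3-yl in place of 4-methylphenyl on an aromatic carbon, with the group sitting on an aromatic carbon of a five-membered aromatic ring with two nitrogen, part of a fused system of two rings. Since compound 1 is known only to the limit < 5000 nM, the step is expected to be modest, towards higher solubility, with little confidence. Compound 3 is therefore estimated at 8000 nM, between 2000 nM and 30000 nM, a change of an at least 1.6-fold higher number from compound 1 to compound 3 (0.20 log units; that floor lies within the scatter).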

Compound 3, solubility: 9000 nM
Estimate against measurement, compound 3: 1.1-fold (0.05 log units) below; the range from low to high includes it.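

Within the data shown here, with thiophen-3-yl in place of 4-methylphenyl on an aromatic carbon of the five-membered aromatic ring with 2 nitrogen, this assay gives a first reading for this position, a change of an at least 1.8-fold higher number from compound 1 to compound 3 (0.25 log units; that floor lies within the scatter). Compound 1 stands only at a limit, so this step is a floor and not a full size: the limit of < 5000 nM in this assay, at which 1 of the 3 values shown sits.

Compound 3, with its five-membered aromatic ring with 1 hetero atom, gives a number rather than a limit, yet the floor alone does not establish a real gain over compound 1.

Going by these compounds, the true distance between compound 1 and compound 3 remains open. So does whether an aliphatic amine or a carboxylic acid on this aromatic carbon would shift the reading in this assay any further.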